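The compounds below may be only part of what the source reports. "The series", "measured", "known", "first", "only" and "open" are said of these compounds alone.

Compound 1 `Cn1c(Cc2nn(C)c(=O)c3ccccc23)nnc1SCCCCCCCC(=O)Nc1ccc(Cl)cc1Cl` is the only one of the three measured compounds to return a number: in an assay on 32D cells for inhibition of interleukin-15 (Mus musculus), read by resazurin assay, with stated times of 30 min and 2.5 days, in the presence of a further agent that is not named here (on this read-out higher numbers stand for weaker inhibition and lower numbers for stronger inhibition), compound 1 gives 2200 nM. Compound 2 `Cn1nc(Cc2nnc(SCC(=O)Nc3ccc(Cl)cc3Cl)n2CCCO)c2ccccc2c1=O` stops at a limit of the assay, and in this assay compound 2 gives > 30000 nM. Compound 3 `Cn1nc(Cc2nnc(SCC(=O)Nc3ccc(Cl)cc3Cl)n2CCC(=O)O)c2ccccc2c1=O` likewise stops at a limit, and in this assay compound 3 gives > 30000 nM. Among the measured compounds shown here, the single measured step, a step that the two limits leave unreadable from compound 2 to compound 3, cannot be read, since both ends sit at the limit of > 30000 nM in this assay, at which 2 of the 3 values shown sit. Compound 4 `Cn1nc(Cc2nnc(SCCCCCCCC(=O)Nc3ccc(Cl)cc3Cl)n2CCCO[Si](C)(C)C(C)(C)C)c2ccccc2c1=O` differs from compound 1 by a group of 10 heavy atoms (8 carbon, 1 oxygen, 1 silicon; no ring) in place of a hydrogen atom, on a saturated chain carbon bound to an aromatic nitrogen. For the measured compounds named here, no measured step tracks this change, so its size and direction in this assay remain open. For compound 4 the expected step is a 1.4-fold higher number from compound 1 to compound 4 (0.13 log units; within the scatter). The estimate for compound 4 in this assay is 3000 nM, between 800 nM and 15000 nM.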

Compound 4, half-maximal inhibitory concentration: > 30000 nM
Compound 4 was reported as a limit; the forecaster's own chance of this, stated with the estimate: 20%; middle value at least 10-fold (1.00 log units) from the limit.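

In this assay, among the compounds shown here, this is the first readable step at this place, a saturated chain carbon bound to an aromatic nitrogen, and the site does not take the change without loss: a group of 10 heavy atoms (8 carbon, 1 oxygen, 1 silicon; no ring) in place of a hydrogen atom gives an at least 13-fold higher number from compound 1 to compound 4 (1.13 log units; beyond the scatter). Compound 4 stands at a limit of the assay, so this step gives only a bound and not a size: the limit of > 30000 nM in this assay, at which 3 of the 4 values shown sit.

The compounds shown leave open how a plain ethyl chain or an aminopropyl chain at this place would read against compound 1.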